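Changing One Aryl Group on a Potent Amide

The compounds below may be only part of what the source reports. "The series", "measured", "known", "first", "only" and "open" are said of these compounds alone.

In a functional assay on SK-OV-3 cells (Homo sapiens) for antiproliferative activity, read by MTT assay, with a stated time of 72 h (on this read-out lower numbers stand for stronger inhibition and higher numbers for weaker inhibition), compound 1 `O=C(CCc1cccc2c1B(O)OC2)Nc1ccccc1` gives 200 nM. Compound 2 `O=C(CCc1cccc2c1B(O)OC2)Nc1cccc(-c2cccc(F)c2)c1` gives 480 nM, and compound 3 `COc1cc(OC)cc(-c2cccc(NC(=O)CCc3cccc4c3B(O)OC4)c2)c1` gives 44 nM, the lowest of the three numbers and so the strongest inhibition seen so far. Compound 4 `CSc1cccc(-c2cccc(NC(=O)CCc3cccc4c3B(O)OC4)c2)c1` keeps the shared core and alters one group, with 3-(methylsulfanyl)phenyl in place of 3,5-dimethoxyphenyl on an aromatic carbon.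

Within the data shown here, three measured steps bear on this change. Adding an aromatic group moved the number either way: a 2.4-fold higher number from compound 1 to compound 2 (0.38 log units; beyond the scatter) with 3-fluorophenyl, and a 4.5-fold lower number from compound 1 to compound 3 (0.66 log units; beyond the scatter) with 3,5-dimethoxyphenyl. Exchanging those two groups gave the largest step, an 11-fold lower number from compound 2 to compound 3 (1.04 log units; beyond the scatter), so a swap at this place can matter a great deal. The new group has not been tested, so the direction is only a cautious expectation. Among the measured compounds shown here, a moderate rise is expected because compound 3 at 44 nM holds the lowest number so far. The expected step is a 2.7-fold higher number from compound 3 to compound 4 (0.44 log units; beyond the scatter). For compound 4 the estimated value is 120 nM, with an expected range of 35 nM to 400 nM.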

Compound 4, half-maximal inhibitory concentration: 150 nM
The estimate for compound 4 lay 1.3-fold (0.10 log units) below the measured number; the range from low to high includes it.
By their numbers in this assay, from the lowest: compound 3; then compounds 4 and 1 (each within the scatter of the next); then compound 2.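

Putting 3-(methylsulfanyl)phenyl in place of 3,5-dimethoxyphenyl in this assay gives a 3.4-fold higher number from compound 3 to compound 4 (0.53 log units; beyond the scatter) and so shows that not every substituted phenyl at this place matches that low number. Methylsulfanyl in place of fluoro gives a 3.2-fold lower number from compound 2 to compound 4 (0.51 log units; beyond the scatter) so one small group on the added phenyl ring is enough to move the number by more than the usual scatter. Adding 3-(methylsulfanyl)phenyl to the unsubstituted amide gives a 1.3-fold lower number from compound 1 to compound 4 (0.12 log units; within the scatter) which reveals a third outcome at this place, besides the clear rise and the clear fall seen earlier.

Nothing measured here explains why these groups differ. From the compounds shown here alone, it also remains open how a phenyl ring carrying an amine or a carboxylic acid at this place would compare with these compounds.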